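Oxazoline for Thiazoline: A Sulfonyl Side-Chain Swap

The source may hold more compounds than are shown below. What is called first, only, known or untested is meant among the compounds shown, and "the series" means these compounds.

Measured compounds:
compound 1 `COc1ccc(C2=NN(c3ccccc3)C(c3ccc(C)cc3)C2S(=O)(=O)CC2=NCCO2)cc1`: 70.5%
compound 2 `COc1ccc(C2=NN(c3ccccc3)C(c3ccc(C)cc3)C2S(=O)(=O)CC2=NCCS2)cc1`: 50.7%
compound 3 `O=S(=O)(CC1=NCCS1)c1c(-c2ccccc2)noc1-c1ccccc1`: "not active" (no number reported), with no number

In a functional assay, read by Griess assay, with a stated time of 150 min, tested at 100 ug/mL (on this read-out higher numbers stand for a stronger effect at the one concentration tested and lower numbers for a weaker effect), compound 1 gives 70.5% and compound 2 gives 50.7%. The two differ only by a group of 5 heavy atoms (3 carbon, 1 nitrogen, 1 oxygen; one five-membered non-aromatic ring with 2 hetero atoms) in place of a group of 5 heavy atoms (3 carbon, 1 nitrogen, 1 sulfur; one five-membered non-aromatic ring with 2 hetero atoms), on a saturated chain carbon bound to a sulfonyl sulfur, and this gave a number 19.8 percentage points higher from compound 2 to compound 1 (beyond the scatter). Compound 3 shares no counted difference with compound 2; the difference between the two cores is not broken down here. Compound 4 `O=S(=O)(CC1=NCCO1)c1c(-c2ccccc2)noc1-c1ccccc1` is the unmeasured partner of compound 3 and differs from it by a group of 5 heavy atoms (3 carbon, 1 nitrogen, 1 oxygen; one five-membered non-aromatic ring with 2 hetero atoms) in place of a group of 5 heavy atoms (3 carbon, 1 nitrogen, 1 sulfur; one five-membered non-aromatic ring with 2 hetero atoms), on a saturated chain carbon bound to a sulfonyl sulfur, the same change seen between compound 2 and compound 1. Since compound 3 was reported as "not active" (no number reported), the expectation for compound 4 rests on compound 3 being weak and on the step of a number 19.8 percentage points higher from compound 2 to compound 1 (beyond the scatter) in the other core. Compound 4 is therefore expected to give 20% in this assay, estimated between 0% and 45%.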

Compound 4, a percentage reported as activity, at one concentration (the size of the read-out at that concentration, not a potency): 62.1%
Compound 4: the middle estimate sits 42.1 percentage points below what was measured, outside the stated range (above it).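

Going by these compounds alone, compound 3 is reported only as "not active", without a number, so no step to compound 4 can be read. From the compounds shown here alone, how large the ring swap's effect is in this core remains open. No measured evidence here accounts for the result.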